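The source may hold more compounds than are shown below. What is called first, only, known or untested is meant among the compounds shown, and "the series" means these compounds.

Working notes on the series. In a toxicity assay on GES1 cells (Homo sapiens) for inhibition, read by MTT assay, with a stated time of 72 h (a higher number here means a weaker inhibitor, a lower number a stronger inhibitor), compound 1 `Cc1cc(N2CC[C@@H](C)[C@@H](N(C)c3ncnc4[nH]ccc34)C2)n2nc(SCc3ccc([N+](=O)[O-])cc3)nc2n1` gives 36600 nM. Compound 2 `Cc1cc(N2CC[C@@H](C)[C@@H](N(C)c3ncnc4[nH]ccc34)C2)n2nc(SCc3ccc(F)c(Cl)c3)nc2n1` reaches only the limit of > 100000 nM in this assay, a limit and not a number. Compound 3 `COc1ccc(CSc2nc3nc(C)cc(N4CC[C@@H](C)[C@@H](N(C)c5ncnc6[nH]ccc56)C4)n3n2)cc1` likewise reaches only the limit of > 100000 nM in this assay, so compound 3 stands at the weak end of what is shown, sharing (the limit of > 100000 nM in this assay, at which 2 of the 3 values shown sit). Compound 4 `Cc1cc(N2CC[C@@H](C)[C@@H](N(C)c3ncnc4[nH]ccc34)C2)n2nc(SCc3csc4ccc(Cl)cc34)nc2n1` is not yet measured; it differs from compound 3 by 5-chloro-1-benzothiophen-3-yl in place of 4-methoxyphenyl on a saturated chain carbon bound to a sulfur. Going by the values given here, the steps that bear on swapping the group on the saturated chain carbon bound to a sulfur are an at least 2.7-fold higher number from compound 1 to compound 2 (0.43 log units; beyond the scatter) and a step that the two limits leave unreadable from compound 2 to compound 3, both touching the limit. For compound 4 the expected step is a number no higher from compound 3 to compound 4 (the limit leaves the size open), so compound 4 is estimated at 100000 nM, between 30000 nM and 300000 nM.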

Compound 4, half-maximal inhibitory concentration: > 100000 nM
Compound 4: no number, only a limit; the forecaster's own chance of this, stated with the estimate: 70%; the middle value sits exactly at the limit.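

On the saturated chain carbon bound to a sulfur, 5-chloro-1-benzothiophen-3-yl, with a five-membered and a six-membered aromatic ring, also reaches only a limit in this assay, as the single-ring groups of compound 2 and compound 3 do, and the 4-nitrophenyl of compound 1 remains the only group with a number: the limit of > 100000 nM in this assay, at which 3 of the 4 values shown sit.

Going by these compounds alone, the one readable step is an at least 2.7-fold higher number from compound 1 to compound 4 (0.43 log units; beyond the scatter); the steps among the compounds at the limit cannot be read.

On these data alone, whether an amine or a carboxylic acid in place of the nitro group, or a longer chain on the sulfur, would give a number in this assay stays open. As far as these compounds go, the order of compound 2, compound 3 and compound 4 beyond the limit also stays open.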